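Replacing the proline acid of compound 1 with a valine acid

A few compounds are considered here, and "the series" means these few. Any claim that something is new, unique, unknown or untested is made for them only; others in the source may bear on it.

Measured compounds:
compound 1 `O=C(O)[C@@H]1CCCN1C(=O)CN(c1nc(Cl)nc2[nH]cnc12)C1CC1` gives 31.5%
compound 2 `CSCC[C@H](NC(=O)CN(c1nc(Cl)nc2[nH]cnc12)C1CC1)C(=O)OCc1ccccc1` gives 22.2%
compound 3 `O=C(OCc1ccccc1)[C@@H]1CCCN1C(=O)CN(c1nc(Cl)nc2[nH]cnc12)C1CC1` gives 33.2%

These three compounds share a core and were tested in a functional assay on the whole organism (Tail, strain ICR) with Mus musculus as the target, in the tail flick test, with a stated time of 30 min, at a dose of 25 umol/kg by the oral route; on this read-out higher numbers stand for a stronger effect at the one dose given and lower numbers for a weaker effect. Compound 1 stands second highest of the three numbers, with compound 3 nearest and compound 2 furthest; both gaps lie within the scatter, so no order among the three can be claimed. For the measured compounds named here, the one single-place step that has been measured is a number 1.7 percentage points higher from compound 1 to compound 3 (within the scatter), a change on the oxygen of the acid that did not move the read-out beyond the scatter.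

Compound 4 `CC(C)[C@H](NC(=O)CN(c1nc(Cl)nc2[nH]cnc12)C1CC1)C(=O)O` has not yet been measured in this assay. It differs from compound 1 in one place: (1-carboxy-2-methylpropyl)amino in place of 2-carboxypyrrolidin-1-yl on a carbonyl carbon. Going by the values given here, no measured step touches the amino-acid part of the chain directly. Compound 2 and compound 3 both carry a benzyl ester and differ in their amino-acid part, and their two values show a gap that still lies within the scatter. Compound 4 is therefore expected to sit near compound 1, with a step of a number 4.5 percentage points lower from compound 1 to compound 4 (within the scatter) that is estimated to stay within the scatter. The estimate for compound 4 in this assay is 27%, with a range from 14% to 39%.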

Compound 4, a percentage reported as activity, at one dose (the size of the read-out at that dose, not a potency): 31.2%
Estimate against measurement, compound 4: 4.2 percentage points below; low and high end bracket the measured number.
By their numbers in this assay, from the lowest: compounds 2, 4, 1 and 3 (each within the scatter of the next, the first and the last beyond it).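

In this assay, for the compounds shown here, putting (1-carboxy-2-methylpropyl)amino in place of 2-carboxypyrrolidin-1-yl on a carbonyl carbon gives a number 0.3 percentage points lower from compound 1 to compound 4 (within the scatter), the first measured step that touches the amino-acid part itself rather than the oxygen of the acid. The five-membered ring is gone in the entering group and one more hydrogen-bond donor is counted, while the heavy atom count stays the same, and still the read-out does not move beyond the scatter, so at this single dose the ring is not required for the effect seen with the free acid. Nothing available bears on why this exchange leaves the read-out in place.

As far as these compounds go, it remains open whether any group at this place can move the read-out beyond the scatter, for instance a primary carboxamide in place of the carboxylic acid, or a longer alkyl chain in place of the 2-methylpropyl part. Since every number here comes from one dose, the compounds shown also leave open whether the ring and the open chain would still match at other doses.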